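Benzyloxy for methoxy in a series held at the limit

The source may report more compounds than this note shows. Statements on the series, on what has been measured and on what is new or still open speak of the compounds shown alone.

Measured so far in an ADME assay on HepG2 cells (Homo sapiens) for cytotoxicity, read by MTT assay, with a stated time of 24 h (a higher number here means a weaker inhibitor, a lower number a stronger inhibitor), each entry a limit of the assay and not a number:
- compound 1 `CCOS(=O)(=O)/C=C/c1ccc(OCC2=CC[C@@H]3C(C(=O)Nc4ccc(Oc5ccc(-c6ccccc6)cc5)cc4)=CO[C@@H](OC)[C@H]23)cc1` gives > 200000 nM
- compound 2 `CCOS(=O)(=O)/C=C/c1ccc(OCC2=CC[C@@H]3C(C(=O)Nc4ccc(Oc5ccc(Br)cc5Cl)cc4)=CO[C@@H](OC)[C@H]23)cc1` gives > 200000 nM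
- compound 3 `CCOS(=O)(=O)/C=C/c1ccc(OCC2=CC[C@@H]3C(C(=O)Nc4ccc(Oc5ccc6ccccc6c5)cc4)=CO[C@@H](OC)[C@H]23)cc1` gives > 200000 nM

Compound 2 gives only the limit > 200000 nM and no number. The wider record is the limit of > 200000 nM in this assay, at which 3 of the 3 values shown sit, and no measured value stands clear of it.

Compound 4 `CCOS(=O)(=O)/C=C/c1ccc(OCC2=CC[C@@H]3C(C(=O)Nc4ccc(Oc5ccc(Br)cc5Cl)cc4)=CO[C@@H](OCc4ccccc4)[C@H]23)cc1` carries the change phenyl in place of hydrogen on a saturated chain carbon bound to an oxygen on a saturated carbon on compound 2, which reads methoxy to benzyloxy when cut one bond further out. The measured steps bear on this only indirectly, since all of them fall on an oxygen on an aromatic ring and not at this place. They are a step that the two limits leave unreadable from compound 1 to compound 2 and a step that the two limits leave unreadable from compound 1 to compound 3 and a step that the two limits leave unreadable from compound 2 to compound 3 with no size to carry over.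

The expectation therefore rests on the limit of compound 2 at > 200000 nM and on little else. An estimated a number no higher from compound 2 to compound 4 (the limit leaves the size open) follows, so no step beyond the scatter and no direction is expected in this assay here. For compound 4 the expected value is 200000 nM with an estimated range from 90000 nM to 400000 nM and a fair chance of a bare limit again.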

Compound 4, half-maximal inhibitory concentration: > 200000 nM
Compound 4: a limit, no number; the forecaster's own chance of this, stated with the estimate: 75%; the middle value lies on the limit itself.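

In this assay compound 2 and compound 4 each give only a limit and no number, so no step can be read for the change from methoxy to benzyloxy. The compounds shown leave open how far any of them lies from that limit, and whether any change on the shared core gives a measured number: the limit of > 200000 nM in this assay, at which 4 of the 4 values shown sit.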